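Swapping a pyridine for a tert-butyl on the alkyne arm

The compounds below may be only part of what the source reports. "The series", "measured", "known", "first", "only" and "open" are said of these compounds alone.

Compound 1 `Cn1cncc1C(OCc1ccc(C#N)cc1C#Cc1ccccn1)c1ccc(C#N)cc1` is measured in a functional assay on NIH3T3 cells (Mus musculus) (a higher number here means that more compound is needed for the effect, a lower number that less compound is needed), only as a limit, > 0.1 nM, so no exact number stands for it. Compound 2 `Cn1cncc1C(OCc1ccc(C#N)cc1C#CCCCCO)c1ccc(C#N)cc1` gives 20.9 nM in this assay. The change from compound 1 to compound 3 `Cn1cncc1C(OCc1ccc(C#N)cc1C#CC(C)(C)C)c1ccc(C#N)cc1` is tert-butyl in place of pyridin-2-yl on a triple-bonded carbon. Among the compounds with values here, the only related step, a step that the limit leaves unreadable from compound 1 to compound 2, cannot be sized because of the limit (the limit of > 0.1 nM in this assay, at which 1 of the 2 values shown sits), so it offers no guide to direction or size. Within the data shown here, compound 3 is therefore expected near the one firm number available, at about 30 nM, somewhere between 5 nM and 200 nM, which would mean an estimated step that the limit leaves unreadable from compound 1 to compound 3.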

Compound 3, half-maximal effective concentration: 76.9 nM
Beside the measured number, compound 3's estimate is 2.6-fold (0.41 log units) below it; low and high end bracket the measured number.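

This position, on a triple-bonded carbon, now has its first readable step: tert-butyl in place of 4-hydroxybutyl gives a 3.7-fold higher number from compound 2 to compound 3 (0.57 log units; beyond the scatter) in this assay. Compound 1 is known only as a limit, so the steps from it cannot be read: the limit of > 0.1 nM in this assay, at which 1 of the 3 values shown sits.

As far as these compounds go, whether pyridin-2-yl gives a lower or a higher number than either of the other two groups therefore stays open. A plain butyl chain or an amine at the end of the chain would show whether the hydroxyl of 4-hydroxybutyl, rather than the shape of the chain, goes with the lower number of compound 2.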